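Swapping 4-hydroxy-2-methylphenyl for 4-ethylphenyl

A few compounds are considered here, and "the series" means these few. Any claim that something is new, unique, unknown or untested is made for them only; others in the source may bear on it.

In a functional assay on NCI-H460 cells (Homo sapiens) for inhibition, read by sulforhodamine B assay, with a stated time of 48 h (a lower number here means a stronger inhibitor of growth, a higher number a weaker inhibitor of growth), compound 1 `Cc1ccc(C2=NN(c3ccc(S(C)(=O)=O)cc3)C(=O)CC2)cc1` gives 380 nM, and compound 2 `Cc1cc(O)ccc1C1=NN(c2ccc(S(C)(=O)=O)cc2)C(=O)CC1` gives 3870 nM, the higher of the two numbers. Among the measured compounds shown here, the only measured step is a 10-fold higher number from compound 1 to compound 2 (1.01 log units; beyond the scatter), and it comes with 4-hydroxy-2-methylphenyl taking the place of 4-methylphenyl on a carbon with a double bond to nitrogen.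

Compound 3 `CCc1ccc(C2=NN(c3ccc(S(C)(=O)=O)cc3)C(=O)CC2)cc1` has not yet been measured. It differs from compound 2 in having 4-ethylphenyl in place of 4-hydroxy-2-methylphenyl on that same carbon: 4-ethylphenyl in place of 4-hydroxy-2-methylphenyl on a carbon with a double bond to nitrogen. The change removes the group that entered in the measured step, and the incoming 4-ethylphenyl resembles the 4-methylphenyl of compound 1 more closely than it resembles the group it replaces. For the measured compounds named here, no measured compound here carries 4-ethylphenyl, so the size of this swap has no direct precedent, and the one measured step is the only guide. A large move toward a lower number is therefore expected, roughly undoing that step. The expected step is a 9.7-fold lower number from compound 2 to compound 3 (0.99 log units; beyond the scatter). For compound 3 the estimate is 400 nM, with an expected range from 150 nM to 1100 nM.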

Compound 3, concentration for 50% growth inhibition: 820 nM
Estimate against measurement, compound 3: 2.1-fold (0.31 log units) below; the measured number falls inside the stated range.
By their numbers in this assay, from the lowest: compound 1; then compound 3; then compound 2.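

In this assay, methyl in place of hydrogen on the saturated chain carbon bound to an aromatic carbon gives a 2.2-fold higher number from compound 1 to compound 3 (0.33 log units; beyond the scatter) as a modest step, so even this small extension of the 4-methylphenyl group moves the number beyond the scatter. The swap of 4-hydroxy-2-methylphenyl for 4-ethylphenyl gives a 4.7-fold lower number from compound 2 to compound 3 (0.67 log units; beyond the scatter) and thus recovers only part of the large step seen earlier, leaving compound 3 between compound 1 and compound 2. Both groups have 8 heavy atoms, so on this carbon the heavy-atom count alone does not set the number, and the data shown offer no explanation for either step.

The compounds shown do not separate the hydroxy group from the added methyl of 4-hydroxy-2-methylphenyl, so it remains open how much of the higher number of compound 2 belongs to each. On these data alone, it is also open whether the rise from 4-methylphenyl to 4-ethylphenyl continues with a longer chain such as propyl, and how a methoxy group or an amine would compare in place of the ethyl group.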